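The compounds below may be only part of what the source reports. "The series", "measured", "known", "first", "only" and "open" are said of these compounds alone.

Measured in a functional assay on MCF7 cells (Homo sapiens) for antiproliferative activity, read by MTT assay, with a stated time of 72 h; on this read-out lower numbers stand for stronger inhibition and higher numbers for weaker inhibition: compound 1 `COc1cc(-n2cnc3ccc(-c4cc(F)ccc4F)cc32)cc(OC)c1OC` gives 6420 nM; compound 2 `COc1cc(-n2cnc3ccc(-c4ccc([N+](=O)[O-])cc4)cc32)cc(OC)c1OC` gives 740 nM; compound 3 `COc1cc(-n2cnc3ccc(-c4ccccc4)cc32)cc(OC)c1OC` gives 2290 nM.

Compound 1 stands highest of these three numbers, with a 2.8-fold lower number from compound 1 to compound 3 (0.45 log units; beyond the scatter) to the nearest of them and an 8.7-fold lower number from compound 1 to compound 2 (0.94 log units; beyond the scatter) to the furthest. Compound 4 `COc1cc(-n2cnc3ccc(-c4ccc(Cl)cc4Cl)cc32)cc(OC)c1OC` differs from compound 1 in one place: 2,4-dichlorophenyl in place of 2,5-difluorophenyl on an aromatic carbon. Within the data shown here, no measured step exchanges one dihalogenated ring for another, so the only guidance is indirect: the two changes made at this same position, a 2.8-fold lower number from compound 1 to compound 3 (0.45 log units; beyond the scatter) and an 8.7-fold lower number from compound 1 to compound 2 (0.94 log units; beyond the scatter), both gave modest moves toward lower numbers. A step of at most modest size is therefore expected in this assay, more likely toward a lower number than a higher one, and quite possibly within the scatter. Compound 4 is estimated at 4000 nM, in the range 1500 nM to 12000 nM, which is an expected 1.6-fold lower number from compound 1 to compound 4 (0.21 log units; within the scatter).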

Compound 4, half-maximal inhibitory concentration: 5420 nM
Estimate against measurement, compound 4: 1.4-fold (0.13 log units) below; low and high end bracket the measured number.
By their numbers in this assay, from the lowest: compound 2; then compound 3; then compounds 4 and 1 (each within the scatter of the next).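

In this assay, exchanging one dihalogenated ring for the other leaves the number essentially in place, with a 1.2-fold lower number from compound 1 to compound 4 (0.07 log units; within the scatter), and a change of halogen together with a change in their placing thus has no readable effect here. The 2,4-dichlorophenyl group, like the 2,5-difluorophenyl group, stands on the weak side of this small series, with a 2.4-fold higher number from compound 3 to compound 4 (0.37 log units; beyond the scatter) and a 7.3-fold higher number from compound 2 to compound 4 (0.86 log units; beyond the scatter). No measurement available here explains these differences. As far as these compounds go, whether the halogen or its placing matters more stays open, as does how an amine or a carboxylic acid in place of the nitro group would compare with compound 2.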